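The source may hold more compounds than are shown below. What is called first, only, known or untested is meant among the compounds shown, and "the series" means these compounds.

Compound 1 `Cc1cn(-c2cc(NC(=O)c3ccc(C)c(Nc4nc(-c5cccnc5)cs4)c3)cc(C(F)(F)F)c2)cn1`: 28 nM
Compound 2 `Cc1ncn(-c2cc(NC(=O)c3ccc(C)c(Nc4nc(-c5cccnc5)cs4)c3)cc(C(F)(F)F)c2)n1`: 26 nM
Compound 3 `Cc1cn(-c2cc(NC(=O)c3cccc(Nc4nc(-c5cccnc5)cs4)c3)cc(C(F)(F)F)c2)cn1`: 3190 nM

All three were tested in a functional assay on K562 cells (Homo sapiens) for antiproliferative activity; on this read-out lower numbers stand for stronger inhibition and higher numbers for weaker inhibition. Compound 3 shows the highest number of the three. Among the compounds with values here, its nearest neighbour is compound 1, and the single change between them, hydrogen in place of methyl on an aromatic carbon, gave a 110-fold higher number from compound 1 to compound 3 (2.06 log units; beyond the scatter). Compound 1 and compound 2 differ in a different part of the molecule, and there the step of a 1.1-fold lower number from compound 1 to compound 2 (0.03 log units; within the scatter) stays within the scatter.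

Compound 4 `CCc1ccc(C(=O)Nc2cc(-n3cnc(C)c3)cc(C(F)(F)F)c2)cc1Nc1nc(-c2cccnc2)cs1` has not yet been measured. It differs from compound 3 by ethyl in place of hydrogen on an aromatic carbon: the ethyl group, two carbon atoms and no ring, sits on an aromatic carbon of a six-membered aromatic ring of carbon only, ortho to a (4-(pyridin-3-yl)-1,3-thiazol-2-yl)amino group and para to a large group. That is the same place where compound 1 carries its methyl. Within the data shown here, the only measured step bearing on this change is the large one seen on removing that methyl, a 110-fold higher number from compound 1 to compound 3 (2.06 log units; beyond the scatter), so putting a small alkyl group back is expected to lower the number strongly. Among the measured compounds shown here, no measured pair shows how ethyl compares with methyl at this place, so the range is kept wide. Compound 4 is therefore expected to give about 60 nM in this assay, between 15 nM and 400 nM, meaning an expected step of a 53-fold lower number from compound 3 to compound 4 (1.73 log units; beyond the scatter).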

Compound 4, half-maximal inhibitory concentration: 1600 nM
The estimate for compound 4 lay 27-fold (1.43 log units) below the measured number; the whole stated range lies below it.
By their numbers in this assay, from the lowest: compounds 2 and 1 (each within the scatter of the next); then compounds 4 and 3 (each within the scatter of the next).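

In this assay, the place that compound 1 fills with methyl does not simply accept any small alkyl group: ethyl there gives a number that cannot be told apart from that of the compound carrying only hydrogen (a 2.0-fold lower number from compound 3 to compound 4 (0.30 log units; within the scatter)). Lengthening the methyl of compound 1 by this single step to ethyl costs almost as much as removing the methyl altogether (a 57-fold higher number from compound 1 to compound 4 (1.76 log units; beyond the scatter)), so among these three compounds the strong inhibition is seen only with methyl, and a larger alkyl group does not retain it. Nothing available here gives a measured reason for this sharp difference between methyl and ethyl.

The compounds shown leave open whether anything other than methyl can work at this place, such as a chlorine atom, a methoxy group or a longer chain like propyl, which would show whether the requirement is as narrow as these three compounds suggest. They also leave open whether ethyl behaves the same way when the 4-methyl-1H-imidazol-1-yl group is replaced by the 3-methyl-1H-1,2,4-triazol-1-yl group of compound 2.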